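The source may report more compounds than this note shows. Statements on the series, on what has been measured and on what is new or still open speak of the compounds shown alone.

Compound 2, whose structure is `CCC1C(=O)N(C)c2cnc(Nc3ccc(S(=O)(=O)NCCCO)cc3)nc2N1c1ccn(C)n1`, sits at the weak end of the three results gathered so far in a functional assay on A549 cells (Homo sapiens) for antiproliferative activity, read by CCK-8 assay, with a stated time of 72 h; a higher number here means a weaker inhibitor of growth, a lower number a stronger inhibitor of growth. In this assay compound 2 gives 48900 nM, whereas compound 1, with the structure `CC[C@@H]1C(=O)N(C)c2cnc(Nc3ccc(S(=O)(=O)NC4CCCC4)cc3)nc2N1C1CCCC1`, gives 1150 nM, and compound 3, with the structure `CCCCNC(=O)c1ccc2c(ccn2-c2ncc3c(n2)N(C2CCCC2)[C@H](CC)C(=O)N3C)c1`, gives 1160 nM. Both of those numbers lie well beyond the scatter from compound 2, so compound 2 is the weakest of the three; compounds 1 and 3 themselves cannot be ordered against each other.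

Compound 4, with the structure `CCC1C(=O)N(C)c2cnc(Nc3ccc(S(N)(=O)=O)cc3)nc2N1c1ccn(C)n1`, is the next point of comparison. Its difference from compound 2 is hydrogen in place of 3-hydroxypropyl on a sulfonamide nitrogen, the (3-hydroxypropyl)sulfamoyl group becoming a sulfamoyl group. Going by the values given here, no measured pair isolates this change, so its size is not known from the data. The sulfonamide substituent differs among all three measured compounds and nothing ties the 3-hydroxypropyl group to the high number of compound 2. Compound 4 is therefore expected to stay close to compound 2, with a step of a 1.6-fold lower number from compound 2 to compound 4 (0.21 log units; within the scatter) that may not exceed the scatter, and an estimated value of 30000 nM, between 8000 nM and 120000 nM.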

Compound 4, concentration for 50% growth inhibition: "not active" (no number reported)
Nothing numeric was reported for compound 4, so the estimate cannot be set against anything.
By their numbers in this assay, from the lowest: compounds 1 and 3 (each within the scatter of the next); then compound 2.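

In this assay, going by these compounds alone, compound 4 is recorded as "not active" with no number, so no step from compound 2 to compound 4 can be read. Nothing available bears on this result. As far as these compounds go, how the sulfonamide substituent alone affects growth inhibition stays open.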